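Amino in place of hydrogen at the cytotoxicity limit

A few compounds are considered here, and "the series" means these few. Any claim that something is new, unique, unknown or untested is made for them only; others in the source may bear on it.

In an ADME assay on Vero cells (Chlorocebus sabaeus) for cytotoxicity (on this read-out lower numbers stand for stronger inhibition and higher numbers for weaker inhibition), compound 1 (`Cc1cn([C@@H]2S[C@H](CO)C=C2F)c(=O)nc1O`) gives 53000 nM. Compound 2 (`O=c1nc(O)ccn1[C@@H]1S[C@H](CO)C=C1F`) reports only a limit, > 100000 nM. Compound 3 (`O=c1[nH]cnc2c1ncn2[C@@H]1S[C@H](CO)C=C1F`) likewise reports only a limit, > 100000 nM. The starting point is therefore no number but (the limit of > 100000 nM in this assay, at which 2 of the 3 values shown sit).

Compound 4 (`Nc1nc2c(ncn2[C@@H]2S[C@H](CO)C=C2F)c(=O)[nH]1`) has amino in place of hydrogen on an aromatic carbon of compound 3, between two ring nitrogen atoms (amino in place of hydrogen on an aromatic carbon). Within the data shown here, the single measured step is an at least 1.8-fold higher number from compound 1 to compound 2 (0.27 log units; that floor lies within the scatter). It bears only loosely, as it removes a methyl from the core of compound 1 and no amino group appears in any measured compound. Among the measured compounds shown here, with no closer precedent, no change beyond the scatter is expected in this assay, and compound 4 may well report only a limit too. The expected step is a number no higher from compound 3 to compound 4 (the limit leaves the size open). For compound 4 the estimated value is 100000 nM, with an expected range from 40000 nM to 200000 nM.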

Compound 4, half-maximal inhibitory concentration: > 100000 nM
Compound 4: a limit, no number; the forecaster's own chance of this, stated with the estimate: 70%; the middle value lies on the limit itself.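

In this assay compound 3 and compound 4 each report only a limit, so the step between them cannot be read. The compounds shown leave open whether amino in place of hydrogen shifts this read-out at all, as most of the series rests on one limit: the limit of > 100000 nM in this assay, at which 3 of the 4 values shown sit.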